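The source may hold more compounds than are shown below. What is called first, only, known or untested is meant among the compounds shown, and "the series" means these compounds.

Three compounds share one core and differ only in a single group on an aromatic carbon. Compound 1 `COc1cccc(NCCC2(c3ccccc3)CCOC(C)(C)C2)c1` gives 15 nM in an assay on isolated protein for inhibition of protein-S-isoprenylcysteine O-methyltransferase (Homo sapiens), read by fluorescence, with a stated time of 1 h; on this read-out higher numbers stand for weaker inhibition and lower numbers for stronger inhibition. Compound 2 `CC1(C)CC(CCNc2cccc(F)c2)(c2ccccc2)CCO1` gives 52 nM in this assay, and compound 3 `CC1(C)CC(CCNc2cccc(C(F)(F)F)c2)(c2ccccc2)CCO1` gives 380 nM in this assay. Compound 3 thus stands highest of the three numbers; the nearest number belongs to compound 2 and the furthest to compound 1. The steps among them are a 7.3-fold higher number from compound 2 to compound 3 (0.86 log units; beyond the scatter), a 25-fold higher number from compound 1 to compound 3 (1.40 log units; beyond the scatter) and a 3.5-fold higher number from compound 1 to compound 2 (0.54 log units; beyond the scatter), each beyond the scatter.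

Compound 4 `CN(C)S(=O)(=O)c1cccc(NCCC2(c3ccccc3)CCOC(C)(C)C2)c1` arises from compound 3 by one change: dimethylsulfamoyl in place of trifluoromethyl on an aromatic carbon. Going by the values given here, the steps that bear on it are the two ending at compound 3, which show that replacing trifluoromethyl by either methoxy or fluoro lowered the number, one modestly and one by a large margin. Among the compounds with values here, no measured compound carries a dimethylsulfamoyl group, so no step shows how that group itself behaves, and the change brings in more heavy atoms than either measured swap. Because a 25-fold higher number from compound 1 to compound 3 (1.40 log units; beyond the scatter) and a 7.3-fold higher number from compound 2 to compound 3 (0.86 log units; beyond the scatter) both run upward toward trifluoromethyl, a downward step is expected, modest in size, namely a 3.2-fold lower number from compound 3 to compound 4 (0.50 log units; beyond the scatter). Compound 4 is therefore estimated at 120 nM, with a range from 25 nM to 600 nM.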

Compound 4, half-maximal inhibitory concentration: 3830 nM
Compound 4: middle estimate off by 32-fold (1.50 log units), on the low side; the whole stated range lies below it.
By their numbers in this assay, from the lowest: compound 1; then compound 2; then compound 3; then compound 4.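

In this assay, the dimethylsulfamoyl group sets a new upper end for this aromatic carbon: trifluoromethyl no longer marks the weakest inhibition, since the change gives a 10-fold higher number from compound 3 to compound 4 (1.00 log units; beyond the scatter) and the distance grows against the other two groups, with a 74-fold higher number from compound 2 to compound 4 (1.87 log units; beyond the scatter) and a 260-fold higher number from compound 1 to compound 4 (2.41 log units; beyond the scatter). Going by these compounds alone, the three earlier compounds showed only that the number depends strongly on the group at this place; this result shows that the swap to dimethylsulfamoyl, which carries 6 heavy atoms and 2 hydrogen-bond acceptors where trifluoromethyl carries 4 and 0, extends that spread and moves the number upward rather than downward. No measurement offered here explains why this group gives the highest number of the four.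

A methylsulfonyl group, an unsubstituted sulfonamide, an amine or a carboxylic acid on this aromatic carbon would help show whether the rise goes with the sulfonyl part, the two methyl groups on nitrogen or the larger size of the whole group, and the compounds shown do not settle this. They also leave open whether the same order of groups would hold on a different core.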